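A few compounds are considered here, and "the series" means these few. Any claim that something is new, unique, unknown or untested is made for them only; others in the source may bear on it.

Working notes on the series, step from compound 3 to compound 4.

The shared core carries a varying aromatic group on the five-membered aromatic ring with 3 nitrogen. Compound 1 `Nc1cccc(-c2cn(CC(=O)Nc3nccs3)nn2)c1` bears 3-aminophenyl there and in a functional assay on BMDM cells (Mus musculus, strain C57BL/6) for inhibition, with a stated time of 2 days (a lower number here means a stronger inhibitor, a higher number a weaker inhibitor), compound 1 gives 1270 nM. Compound 2 `COc1ccc(-c2cn(CC(=O)Nc3nccs3)nn2)cc1` bears 4-methoxyphenyl, and in this assay compound 2 gives 510 nM. Compound 3 `O=C(Cn1cc(-c2cccs2)nn1)Nc1nccs1` bears thiophen-2-yl. In this assay compound 3 gives only a limit of the assay, > 30000 nM; this is the limit described as the limit of > 30000 nM in this assay, at which 1 of the 3 values shown sits. Compound 3 thus stands at the weak end of the numbers shown, and the change from 3-aminophenyl to thiophen-2-yl gave an at least 23-fold higher number from compound 1 to compound 3 (1.37 log units; beyond the scatter).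

Compound 4 `O=C(Cn1cc(-c2ccc(Cl)cc2)nn1)Nc1nccs1` is not yet measured in this assay. It differs from compound 3 by 4-chlorophenyl in place of thiophen-2-yl on an aromatic carbon. Going by the values given here, the one step that bears on it is the thiophen-2-yl step from compound 1, which runs the other way and was large; the two aryl-bearing compounds 1 and 2 both give numbers, not limits. A return from thiophen-2-yl to a six-membered aromatic ring is therefore expected to give a large step toward a lower number in this assay, roughly an at least 37-fold lower number from compound 3 to compound 4 (1.57 log units; beyond the scatter). For compound 4 the estimate in this assay is 800 nM, within 250 nM to 3000 nM.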

Compound 4, half-maximal inhibitory concentration: 1100 nM
For compound 4 the middle estimate is 1.4-fold (0.14 log units) below the measured one, within the range that was stated.
By their numbers in this assay, from the lowest: compound 2; then compounds 4 and 1 (each within the scatter of the next). At a limit, above all of these: compound 3.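

In this assay, the change to 4-chlorophenyl gives an at least 27-fold lower number from compound 3 to compound 4 (1.43 log units; beyond the scatter), a step that starts from a limit of the assay: the limit of > 30000 nM in this assay, at which 1 of the 4 values shown sits. Chloro in place of methoxy gives a 2.2-fold higher number from compound 2 to compound 4 (0.33 log units; beyond the scatter) and is a modest step, while 4-chlorophenyl in place of 3-aminophenyl gives a 1.2-fold lower number from compound 1 to compound 4 (0.06 log units; within the scatter) and so separates these two groups by no more than the usual scatter. At this position on the five-membered aromatic ring with 3 nitrogen, a third substituted phenyl group therefore gives a number rather than a limit, and among the compounds shown thiophen-2-yl, the only five-membered aromatic ring with 1 hetero atom in this set, is the sole group that ends at a limit.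

The compounds shown leave open whether the gap between thiophen-2-yl and the phenyl groups follows ring size or the ring sulfur, a question that furan-2-yl, thiophen-3-yl or unsubstituted phenyl could address. They also leave open how far the phenyl group tolerates other substituents, such as a carboxylic acid, a dimethylamino group or a longer alkoxy chain.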